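Thioether variation on a shared xanthine-type core

The source may hold more compounds than are shown below. What is called first, only, known or untested is meant among the compounds shown, and "the series" means these compounds.

Measured compounds:
compound 1 `Cn1c(=O)c2c(nc(SCc3ccccc3)n2C)n(C)c1=O` — 8220 nM in an assay on isolated protein for inhibition of Amine oxidase [flavin-containing] A (Homo sapiens), read by fluorescence; a higher number here means a weaker inhibitor, a lower number a stronger inhibitor
compound 2 `CC(C)CCSc1nc2c(c(=O)n(C)c(=O)n2C)n1C` — 15200 nM in this assay
compound 3 `Cn1c(=O)c2c(nc(SC3CCCCC3)n2C)n(C)c1=O` — 24400 nM in this assay

Compound 3 carries the highest number of the three; the gap to compound 2 lies within the scatter, the gap to compound 1 lies beyond it. The two steps into compound 3 are a 3.0-fold higher number from compound 1 to compound 3 (0.47 log units; beyond the scatter) and a 1.6-fold higher number from compound 2 to compound 3 (0.21 log units; within the scatter); the third step, a 1.8-fold higher number from compound 1 to compound 2 (0.27 log units; within the scatter), completes the triangle. Replacing the benzyl group with saturated groups on the sulfur thus moved the number upward by a modest amount at most.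

Compound 4 `Cn1c(=O)c2c(nc(SC3CCCC3)n2C)n(C)c1=O` is not yet measured. It differs from compound 3 by cyclopentyl in place of cyclohexyl on a sulfur. For the measured compounds named here, no measured step exchanges one saturated ring for another of different size, so the expectation rests on the general picture: the saturated thioethers of compound 2 and compound 3 sit close together, and a ring contraction by one carbon is a smaller change than either of the steps already seen. The step from compound 3 to compound 4 is therefore expected to be a 1.2-fold lower number from compound 3 to compound 4 (0.09 log units; within the scatter), that is, no change beyond the scatter, with a slight lean toward a lower number. Compound 4 is estimated at 20000 nM in this assay, with a range from 8000 nM to 50000 nM.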

Compound 4, half-maximal inhibitory concentration: 9400 nM
The estimate for compound 4 lay 2.1-fold (0.33 log units) above the measured number; the measured number falls inside the stated range.
By their numbers in this assay, from the lowest: compounds 1, 4, 2 and 3 (each within the scatter of the next, the first and the last beyond it).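

In this assay, the size of the saturated ring on the sulfur proves able to move the number: contracting cyclohexyl to cyclopentyl gives a step beyond the scatter (a 2.6-fold lower number from compound 3 to compound 4 (0.41 log units; beyond the scatter)), so the saturated thioethers do not behave as one uniform group. Cyclopentyl cannot be told apart from benzyl (a 1.1-fold higher number from compound 1 to compound 4 (0.06 log units; within the scatter)) or from isopentyl (a 1.6-fold lower number from compound 2 to compound 4 (0.21 log units; within the scatter)), since both steps lie within the scatter, and an aromatic ring on the carbon bound to the sulfur is therefore not required for a number in this range. Cyclohexyl in compound 3 stands apart only from benzyl and cyclopentyl, not from isopentyl, and no supporting data on why the two rings differ are available.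

On these data alone, whether the number follows ring size or whether cyclohexyl is a lone exception remains open, and a cyclobutyl or cycloheptyl group on the sulfur would address this. Also open, as far as these compounds go, is how the series responds to a longer chain such as phenethyl, or to an amine or a carboxylic acid carried on the sulfur substituent.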